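Following One Step from the Aminodiol Compound 3

The source may hold more compounds than are shown below. What is called first, only, known or untested is meant among the compounds shown, and "the series" means these compounds.

Measured compounds:
compound 1 `CCCCCCCCc1ccc(CCC(N)(CO)C(=O)O)cc1` — > 10 mg/kg
compound 2 `CCCCCCCCc1ccc(CCC(N)CO)cc1` — > 10 mg/kg
compound 3 `CCCCCCCCc1ccc(CCC(N)(CO)CCCO)cc1` — 0.021 mg/kg

In a functional assay on the whole organism (spleen, spleen) with Rattus norvegicus as the target (a higher number here means that more compound is needed for the effect, a lower number that less compound is needed), compound 3 gives the only number shown; the other two values are limits. Compound 1 reaches only a limit, > 10 mg/kg. Compound 2 likewise reaches only a limit, > 10 mg/kg. The steps of an at least 470-fold lower number from compound 1 to compound 3 (2.67 log units; beyond the scatter) and an at least 470-fold lower number from compound 2 to compound 3 (2.67 log units; beyond the scatter) show that the substitution pattern of compound 3 carries the effect, while a step that the two limits leave unreadable from compound 1 to compound 2.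

Compound 4 `CCCCCCCCc1ccc(CCC(C)(N)CCO)cc1` differs from compound 3 as follows: a group of 6 heavy atoms (4 carbon, 1 nitrogen, 1 oxygen; no ring) in place of a group of 8 heavy atoms (5 carbon, 1 nitrogen, 2 oxygen; no ring), on a saturated chain carbon, two bonds along the chain from an aromatic carbon. Within the data shown here, no measured step covers this change, so the expectation rests on compounds 1 and 2 sitting at the limit of > 10 mg/kg in this assay, at which 2 of the 3 values shown sit, once that pattern is lost. Compound 4 is therefore expected to need more compound, with an estimated step of a 95-fold higher number from compound 3 to compound 4 (1.98 log units; beyond the scatter), giving 2 mg/kg within 0.2 mg/kg to 10 mg/kg.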

Compound 4, dose for 50% inhibition: > 10 mg/kg
Compound 4 gave a limit, no number; the forecaster's own chance of this, stated with the estimate: 35%; middle value at least 5.0-fold (0.69 log units) from the limit.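

In this assay, the group of 6 heavy atoms in place of the group of 8 heavy atoms gives an at least 470-fold higher number from compound 3 to compound 4 (2.67 log units; beyond the scatter). The earlier losses came with carboxy or hydrogen at this carbon, whereas this one comes with neither, so the effect of compound 3 depends on more than avoiding those two groups. Compound 4 gives only a limit, and the steps from compound 1 and compound 2 to it cannot be read: the limit of > 10 mg/kg in this assay, at which 3 of the 4 values shown sit.

The compounds shown leave open whether a 4-hydroxybutyl chain would keep the effect. They also leave open whether an amine could replace the hydroxyl at the end of the 3-hydroxypropyl chain.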